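The compounds below may be only part of what the source reports. "The series", "measured", "known", "first", "only" and "open" are said of these compounds alone.

Measured compounds:
- compound 1 `COc1cc2c(cc1O)CCC(C)(CC(N)=O)O2`: 71200 nM in a functional assay on SH-SY5Y cells (Homo sapiens) for inhibition, read by fluorescence, with a stated time of 1 h; a lower number here means a stronger inhibitor, a higher number a weaker inhibitor
- compound 2 `COc1cc2c(cc1O)CCC(C)(CCNC(C)=O)O2`: 50300 nM in this assay

Within the data shown here, compound 2 gives the lowest of the two numbers, but its only neighbour is compound 1, and the step of a 1.4-fold lower number from compound 1 to compound 2 (0.15 log units; within the scatter) lies within the scatter, so the two are not distinguished. Compound 3 `COc1cc2c(cc1O)CCC(C)(CC(N)C(=O)O)O2` is not yet measured. It differs from compound 2 by amino(carboxy)methyl in place of acetamidomethyl on a saturated chain carbon bound to a saturated ring carbon. Among the measured compounds shown here, the one measured step at this place, a 1.4-fold lower number from compound 1 to compound 2 (0.15 log units; within the scatter), changed little, so no step beyond the scatter is expected here either; the estimated step of a 1.2-fold higher number from compound 2 to compound 3 (0.08 log units; within the scatter) is small. For compound 3 the expected value is 60000 nM, with a range from 20000 nM to 180000 nM.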

Compound 3, half-maximal inhibitory concentration: > 200000 nM
Compound 3 ended at the assay's limit; the forecaster's own chance of this, stated with the estimate: 15%; middle value at least 3.3-fold (0.52 log units) away from the limit.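

At this position the side chain does matter. The earlier exchange of carbamoyl for acetamidomethyl stayed within the scatter, whereas amino(carboxy)methyl gives an at least 3.9-fold higher number from compound 2 to compound 3 (0.59 log units; beyond the scatter) and an at least 2.8-fold higher number from compound 1 to compound 3 (0.44 log units; beyond the scatter). Compound 3 stands at a limit of this assay, not at a number, so the full size of both steps stays unknown: the limit of > 200000 nM in this assay, at which 1 of the 3 values shown sits.

Which part of amino(carboxy)methyl goes with the step remains open, since the amine and the carboxylic acid enter together. A chain bearing only the amine or only the carboxylic acid would separate the two.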